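The source may report more compounds than this note shows. Statements on the series, on what has been measured and on what is new or still open speak of the compounds shown alone.

Measured in a functional assay on A549 cells (Homo sapiens) for antiproliferative activity, with a stated time of 72 h; a lower number here means a stronger inhibitor, a higher number a weaker inhibitor:

compound 1 `COC(=O)CN(C)Cc1c(OC)cc(OC)c(C(=O)/C=C/c2ccccc2Cl)c1O` gives 9100 nM
compound 2 `COc1cc(OC)c(C(=O)/C=C/c2ccccc2Cl)c(O)c1CN1CCCCC1` gives 2800 nM
compound 3 `CCN(C)Cc1c(OC)cc(OC)c(C(=O)/C=C/c2ccccc2Cl)c1O` gives 1300 nM

Compound 3 has the lowest number of the three. Compound 4 `CCN(CC)Cc1c(OC)cc(OC)c(C(=O)/C=C/c2ccccc2Cl)c1O` differs from it by one change, methyl in place of hydrogen on a saturated chain carbon bound to an amine nitrogen, which turns ethyl(methyl)amino into diethylamino: methyl in place of hydrogen on a saturated chain carbon bound to an amine nitrogen. Going by the values given here, no measured step makes this same change. The closest evidence is a 2.2-fold lower number from compound 2 to compound 3 (0.33 log units; beyond the scatter), an exchange of amine groups, and a 7.0-fold lower number from compound 1 to compound 3 (0.85 log units; beyond the scatter), at the same kind of place. Both are modest, and both replace more than this change does. Only a small step is therefore expected, with no clear direction. The expected step is a 1.2-fold higher number from compound 3 to compound 4 (0.06 log units; within the scatter), which would stay within the scatter. For compound 4 the estimated value is 1500 nM, with an expected range from 700 nM to 3300 nM.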

Compound 4, half-maximal inhibitory concentration: 3600 nM
Compound 4: the middle estimate sits 2.4-fold (0.38 log units) below what was measured; the measured number lies above the stated range.
By their numbers in this assay, from the lowest: compound 3; then compounds 2 and 4 (each within the scatter of the next); then compound 1.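

In this assay, a single added methyl at this amine is not a neutral change: turning ethyl(methyl)amino into diethylamino gives a 2.8-fold higher number from compound 3 to compound 4 (0.44 log units; beyond the scatter), so this place responds to one extra carbon. Exchanging piperidin-1-yl for diethylamino gives a 1.3-fold higher number from compound 2 to compound 4 (0.11 log units; within the scatter), while exchanging the amine carrying methoxycarbonyl for diethylamino still gives a 2.5-fold lower number from compound 1 to compound 4 (0.40 log units; beyond the scatter). Nothing available accounts for these steps. As far as these compounds go, how dimethylamino or a morpholine ring would compare at this place remains open.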